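Adding a methyl to compound 1: expected effect on cytotoxicity

A few compounds are considered here, and "the series" means these few. Any claim that something is new, unique, unknown or untested is made for them only; others in the source may bear on it.

Measured so far, in a functional assay on DLA cells (Mus musculus) for cytotoxicity, read by trypan blue exclusion, with a stated time of 48 h; on this read-out lower numbers stand for stronger inhibition and higher numbers for weaker inhibition:
compound 1 `Cc1cc(C(=O)c2ccccc2)ccc1OCC(=O)Nc1nc(-c2ccccc2)cs1` gives 21500 nM
compound 2 `COc1ccc(-c2csc(NC(=O)COc3ccc(C(=O)c4ccccc4)cc3C)n2)cc1` gives 24200 nM
compound 3 `Cc1cc(C(=O)c2ccccc2)cc(C)c1OCC(=O)Nc1nc(-c2ccccc2)cs1` gives 19100 nM

Compound 1 stands second highest of the three numbers, and its two neighbours lie close: the step of a 1.1-fold higher number from compound 1 to compound 2 (0.05 log units; within the scatter) and the step of a 1.1-fold lower number from compound 1 to compound 3 (0.05 log units; within the scatter) both stay within the scatter.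

Compound 4 `Cc1cc(C(=O)c2ccccc2C)ccc1OCC(=O)Nc1nc(-c2ccccc2)cs1` differs from compound 1 by methyl in place of hydrogen on an aromatic carbon. Both measured steps also placed a small group on an aromatic carbon of compound 1 and neither moved the number beyond the scatter, so in this assay the same outcome is expected here, that is a 1.0-fold lower number from compound 1 to compound 4 (0.01 log units; within the scatter). Compound 4 is therefore estimated at 21000 nM, with a range from 10000 nM to 45000 nM.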

Compound 4, half-maximal inhibitory concentration: 22200 nM
Compound 4: middle estimate off by 1.1-fold (0.02 log units), on the low side; the range from low to high includes it.
By their numbers in this assay, from the lowest: compounds 3, 1, 4 and 2 (each within the scatter of the next).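

Going by these compounds alone, compound 4 places its methyl on the phenyl of the benzoyl group, turning benzoyl into (2-methylphenyl)carbonyl, a ring that the earlier steps left unchanged. In this assay the change reads as a 1.0-fold higher number from compound 1 to compound 4 (0.01 log units; within the scatter), so a methyl ortho to a large group on this ring leaves the number unchanged within the scatter. No supporting measurement is available to explain this result.

A single small group cannot show whether this ring accepts every change. An amine, a carboxylic acid or a longer chain at this place could still move the number.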